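The source may report more compounds than this note shows. Statements on the series, on what has been measured and on what is new or still open speak of the compounds shown alone.

In a functional assay on HCT-116 cells (Homo sapiens) for antiproliferative activity (a lower number here means a stronger inhibitor of growth, a higher number a weaker inhibitor of growth), compound 1 `Cc1ccc2c(O)cc(-c3cccc(Cl)c3)nc2n1` gives 25.7 nM, the lower of the two exact numbers. Compound 2 `Cc1cccc(-c2cc(O)c3ccc(C)nc3n2)c1` gives 120 nM. Compound 3 `Cc1ccnc2nc(-c3cccc4ccccc34)cc(O)c12` reports only a limit, < 10 nM. Compound 4 `Cc1cc(C)c2c(O)cc(-c3cccc(Cl)c3)nc2n1` differs from compound 1 by methyl in place of hydrogen on an aromatic carbon, a methyl in place of hydrogen on an aromatic carbon, opposite the ring nitrogen. Going by the values given here, the only measured step, methyl in place of chloro, is a 4.7-fold higher number from compound 1 to compound 2 (0.67 log units; beyond the scatter), but it lies on a different aromatic carbon, so no measured step tests this change directly. No shift beyond the scatter is therefore expected in this assay. The expected step is a 1.3-fold lower number from compound 1 to compound 4 (0.11 log units; within the scatter). For compound 4 the estimated value is 20 nM, with an expected range of 6 nM to 70 nM.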

Compound 4, concentration for 50% growth inhibition: 170 nM
Estimate against measurement, compound 4: 8.5-fold (0.93 log units) below; the whole stated range lies below it.
By their numbers in this assay, from the lowest: compound 1; then compounds 2 and 4 (each within the scatter of the next). At a limit, below all of these: compound 3.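

In this assay, going by these compounds alone, this is the first reading at this position: a methyl in place of hydrogen on an aromatic carbon, opposite the ring nitrogen, gives a 6.6-fold higher number from compound 1 to compound 4 (0.82 log units; beyond the scatter). On the core of compound 1, then, this carbon does not take the added methyl without a loss of growth inhibition beyond the scatter. Nothing measured here accounts for that loss. On these data alone, whether a fluorine, a methoxy group or an amine on this carbon would cost as much remains open. So does whether the methyl has the same effect on compound 2 or compound 3.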